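Swapping the aryl group on a urea-linked Ret inhibitor

The compounds below may be only part of what the source reports. "The series", "measured", "known", "first", "only" and "open" are said of these compounds alone.

Among the measured compounds shown here, compound 2 `Cc1ccc(F)c(NC(=O)Nc2ccc(Nc3ncnc4c3OCCN4)cc2)c1` was tested in an assay on isolated protein for inhibition of proto-oncogene tyrosine-protein kinase receptor Ret variant V804M (Homo sapiens), read by 33P incorporation, with stated times of 15 min and 40 min (a higher number here means a weaker inhibitor, a lower number a stronger inhibitor), where compound 2 gives 5110 nM, the highest of the two numbers measured so far. Its neighbour, compound 1 `O=C(Nc1ccc(Nc2ncnc3c2OCCN3)cc1)Nc1ccc(C(F)(F)F)cc1`, differs only in the aryl group on the urea nitrogen, and in this assay compound 1 gives 276 nM. That single change produced a 19-fold higher number from compound 1 to compound 2 (1.27 log units; beyond the scatter), so this part of the molecule clearly matters. Compound 3 `O=C(Nc1ccc(Nc2ncnc3c2OCCN3)cc1)Nc1cc(Cl)cc(Cl)c1` carries the change (3,5-dichlorophenyl in place of 2-fluoro-5-methylphenyl on an amide-type nitrogen). For the measured compounds named here, since the one comparable step was large, a step of similar scale is expected, estimated as a 6.4-fold lower number from compound 2 to compound 3 (0.81 log units; beyond the scatter) toward stronger inhibition. Compound 3 is therefore estimated at 800 nM, with a range from 200 nM to 3200 nM.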

Compound 3, half-maximal inhibitory concentration: 1300 nM
Compound 3: middle estimate off by 1.6-fold (0.21 log units), on the low side; low and high end bracket the measured number.
By their numbers in this assay, from the lowest: compound 1; then compound 3; then compound 2.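

In this assay the 3,5-dichlorophenyl group gives a middle result, with a 3.9-fold lower number from compound 2 to compound 3 (0.59 log units; beyond the scatter) and a 4.7-fold higher number from compound 1 to compound 3 (0.67 log units; beyond the scatter). This position therefore does more than separate one good group from one poor one: all three aryl groups give clearly different numbers, and compound 1 remains the strongest inhibitor of the three. Nothing available here explains the differences. Still open, on these data alone, is how the urea nitrogen would tolerate an aryl ring bearing a methoxy group or an amine. A saturated ring such as cyclohexyl in place of the aryl ring is also untested here.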